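Ethyl in place of methyl on a weaker pyrazole core

The source may hold more compounds than are shown below. What is called first, only, known or untested is meant among the compounds shown, and "the series" means these compounds.

Three close relatives share a core in which an aromatic six-membered ring carries both a pyrazole and an imidazoline-bearing side chain. Compound 1 `Cn1ccc(-c2ccccc2NCC2=NCCN2)n1` is the simplest; in an in vitro functional assay on cells (Fibroblast) for agonist activity at Alpha-1A adrenergic receptor (Homo sapiens) (a lower number here means that less compound is needed, a higher number that more compound is needed for the effect), compound 1 gives 3.16 nM. Compound 2 `CCn1ccc(-c2ccccc2NCC2=NCCN2)n1` differs by methyl in place of hydrogen on a saturated chain carbon bound to an aromatic nitrogen, and in this assay compound 2 gives 25.1 nM; the step is a 7.9-fold higher number from compound 1 to compound 2 (0.90 log units; beyond the scatter). Compound 3 `Cn1cc(-c2ccccc2NCC2=NCCN2)cn1` keeps the methyl on the pyrazole but differs from compound 1 by 1-methyl-1H-pyrazol-4-yl in place of 1-methyl-1H-pyrazol-3-yl on an aromatic carbon, so the two cores carry the same atoms joined differently. In this assay compound 3 gives 398 nM, the step being a 130-fold higher number from compound 1 to compound 3 (2.10 log units; beyond the scatter), and compound 3 stands as the highest of the three numbers.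

Compound 4 `CCn1cc(-c2ccccc2NCC2=NCCN2)cn1` has not yet been measured. It differs from compound 3 by methyl in place of hydrogen on a saturated chain carbon bound to an aromatic nitrogen, and that is the same change already seen from compound 1 to compound 2, made at the same place. Among the compounds with values here, whether the lengthened chain costs as much on the rearranged core cannot be known from these three compounds alone, so the expectation leans on the one measured example, a 7.9-fold higher number from compound 1 to compound 2 (0.90 log units; beyond the scatter), tempered by the chance that the step runs smaller on a core that is already weaker. For compound 4 this means an expected step of a 4.0-fold higher number from compound 3 to compound 4 (0.60 log units; beyond the scatter). Compound 4 is therefore estimated at 1600 nM, with a likely range from 500 nM to 5000 nM.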

Compound 4, half-maximal effective concentration: < 100000 nM
Compound 4 was reported as a limit; the forecaster's own chance of this, stated with the estimate: 10%; the middle value is on the limit's open side.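

In this assay compound 4 is reported as a limit, < 100000 nM, and not as a number. Within the data shown here, no step between compound 3 and compound 4 can be read from this result. The compounds shown leave open whether going from methyl to ethyl on the core of compound 3 changes the number as much as the one readable step of this kind, a 7.9-fold higher number from compound 1 to compound 2 (0.90 log units; beyond the scatter).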